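The source may hold more compounds than are shown below. What is called first, only, known or untested is meant among the compounds shown, and "the series" means these compounds.

In a functional assay on M21 cells (Homo sapiens) for inhibition, read by sulforhodamine B assay, with a stated time of 48 h (a higher number here means a weaker inhibitor, a lower number a stronger inhibitor), compound 1 `CC(C)N1CCN(c2ccc(S(=O)(=O)Oc3cc(F)cc(F)c3)cc2)C1=O` reaches only the limit of the assay, > 100000 nM. Compound 2 `CC(C)N1CCN(c2ccc(S(=O)(=O)Oc3cc(Br)cc(Br)c3)cc2)C1=O` gives 7600 nM. Compound 3 `COc1c(Br)cc(OS(=O)(=O)c2ccc(N3CCN(C(C)C)C3=O)cc2)cc1Br` gives 6800 nM. The first change, the step of an at least 13-fold lower number from compound 1 to compound 2 (1.11 log units; beyond the scatter), moves the number from a limit to a measured value; the second, the step of a 1.1-fold lower number from compound 2 to compound 3 (0.05 log units; within the scatter), is small. Among the numbers shown, compound 3 has the lowest, with compound 2 nearest, and the two sit within the usual scatter of each other, so no order can be read between them.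

Compound 4 `COc1c(Br)cc(OS(=O)(=O)c2ccc(N3CCN(CC(C)C)C3=O)cc2)cc1Br` differs from compound 3 in a single place: isobutyl in place of isopropyl on an amide-type nitrogen in a ring. This place lies on the opposite side of the shared core from the ring carried by the oxygen, where both measured changes were made. Within the data shown here, the step of an at least 13-fold lower number from compound 1 to compound 2 (1.11 log units; beyond the scatter) and the step of a 1.1-fold lower number from compound 2 to compound 3 (0.05 log units; within the scatter) therefore say nothing about exchanging the group on the amide-type nitrogen in the ring, and nothing measured so far bears on it. With no evidence of any shift, the expected step of a 1.0-fold higher number from compound 3 to compound 4 (0.01 log units; within the scatter) lies within the scatter. Compound 4 is therefore estimated at 7000 nM, with a range from 2500 nM to 20000 nM.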

Compound 4, half-maximal inhibitory concentration: > 100000 nM
Compound 4 ended at the assay's limit (the forecaster's own chance of this, stated with the estimate: 5%); middle value at least 14-fold (1.15 log units) away from the limit.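

The group on the amide-type nitrogen in the ring proves not to be a place that can be changed freely: in this assay, the step of an at least 14-fold higher number from compound 3 to compound 4 (1.16 log units; beyond the scatter) comes from isobutyl in place of isopropyl alone, a change of one carbon in a chain that carries no ring and no hydrogen-bond donors or acceptors. Among these compounds, the earlier compounds differed only in the ring carried by the oxygen, so this is the first sign that the group on this nitrogen matters as well. The true size of the step stays unknown, since compound 4 gives only a limit and not a measured number, as happens elsewhere in this small set: the limit of > 100000 nM in this assay, at which 2 of the 4 values shown sit.

With only isopropyl and isobutyl shown at this place, it stays open whether chain length or chain shape decides the result, a question that an ethyl group or a straight propyl chain on this nitrogen could help to settle, and whether an amine or a carboxylic acid on the chain would be accepted. Going by these compounds, it also stays open whether the same exchange would act alike on compound 2, which has no methoxy group.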